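Adding a Phenethylsulfanyl Arm to Compound 1

The source may hold more compounds than are shown below. What is called first, only, known or untested is meant among the compounds shown, and "the series" means these compounds.

Of the compounds shown here, two have so far been measured in a functional assay on HGC-27 cells (Homo sapiens) for inhibition, read by MTT assay, with a stated time of 72 h; a higher number here means a weaker inhibitor, a lower number a stronger inhibitor.

Compound 1 `Cc1cc(N2CC[C@@H](C)[C@@H](N(C)c3ncnc4[nH]ccc34)C2)n2ncnc2n1` gives 11300 nM in this assay.
Compound 2 `Cc1cc(N2CC[C@@H](C)[C@@H](N(C)c3ncnc4[nH]ccc34)C2)n2nc(SCc3csc4ccc(Cl)cc34)nc2n1` gives > 100000 nM in this assay, which is a limit of the assay and not a number.

Going by the values given here, compound 1 therefore stands as the only real number in this assay; the other value shown is a limit. Compound 3 `Cc1cc(N2CC[C@@H](C)[C@@H](N(C)c3ncnc4[nH]ccc34)C2)n2nc(SCCc3ccccc3)nc2n1` differs from compound 1 in a single place: phenethylsulfanyl in place of hydrogen on an aromatic carbon. Among the compounds with values here, the one measured step that bears on this change is an at least 8.8-fold higher number from compound 1 to compound 2 (0.94 log units; beyond the scatter), in which a different sulfur-linked group entered at the same position and the number moved to the limit of > 100000 nM in this assay, at which 1 of the 2 values shown sits. A sulfur-linked group at this position has thus only been seen to weaken inhibition, though on the strength of one step alone. The phenethylsulfanyl group in compound 3 is expected to act in the same direction, and the step of a 5.3-fold higher number from compound 1 to compound 3 (0.73 log units; beyond the scatter) is the estimate for compound 3. Compound 3 is estimated at 60000 nM in this assay, within a range from 15000 nM to 200000 nM, with a real chance that only a limit is reported again.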

Compound 3, half-maximal inhibitory concentration: 11800 nM
Beside the measured number, compound 3's estimate is 5.1-fold (0.71 log units) above it; the measured number lies below the stated range.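

In this assay, phenethylsulfanyl on this carbon of the five-membered aromatic ring leaves inhibition where it was, with a 1.0-fold higher number from compound 1 to compound 3 (0.02 log units; within the scatter). Going by these compounds alone, a sulfur-linked arm at this position therefore does not weaken inhibition in every case, so the single earlier step cannot be read as a rule for all such groups; what matters here is the group carried on the sulfur, as the change from 5-chloro-1-benzothiophen-3-yl to benzyl on the saturated chain carbon gives an at least 8.4-fold lower number from compound 2 to compound 3 (0.92 log units; beyond the scatter). The true size of that step cannot be read, since the value for compound 2 is a limit and not a number: the limit of > 100000 nM in this assay, at which 1 of the 3 values shown sits.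

The compounds shown leave open whether any group at this carbon can give a lower number than compound 1, and whether the chlorine or the fused ring system of the 5-chloro-1-benzothiophen-3-yl group accounts for the gap between the two sulfur-linked compounds. They also leave open what a shorter methylsulfanyl arm, or an amine or a carboxylic acid at the end of the phenethyl chain, would do at this position.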